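The source may report more compounds than this note shows. Statements on the series, on what has been measured and on what is new or still open speak of the compounds shown alone.

Compounds measured so far:
compound 1, `Cc1ccc(-n2cc(CNC(=O)c3cccc4c3cnn4C(C)C)nn2)cc1C`, which in a functional assay on MGC-803 cells (Homo sapiens) for inhibition, read by MTT assay, with a stated time of 72 h (on this read-out lower numbers stand for stronger inhibition and higher numbers for weaker inhibition), gives > 40000 nM, a limit of the assay rather than a number
compound 2, `Cc1ccc(-n2cc(CNC(=O)c3cccc4c3cnn4C(C)C)nn2)cc1`, which gives > 40000 nM, likewise a limit
compound 3, `Cc1ccccc1-n1cc(CNC(=O)c2cccc3c2cnn3C(C)C)nn1`, which gives > 40000 nM, again a limit

Compound 1 thus stands, together with the other two, at the limit of > 40000 nM in this assay, at which 3 of the 3 values shown sit, and no one of the three can be placed above or below another. The step that the two limits leave unreadable from compound 1 to compound 2, the step that the two limits leave unreadable from compound 1 to compound 3 and the step that the two limits leave unreadable from compound 2 to compound 3 are all left unreadable by the two limits involved. Compound 4, `CC(C)n1ncc2c(C(=O)NCc3cn(-c4ccc(C(F)(F)F)cc4)nn3)cccc21`, differs from compound 1 by 4-(trifluoromethyl)phenyl in place of 3,4-dimethylphenyl on an aromatic nitrogen. Within the data shown here, no measured step bears directly on a trifluoromethyl group; the measured steps only show that changing the methyl pattern on the phenyl ring brought none of the compounds into the readable range. The expected step that the limit leaves unreadable from compound 1 to compound 4 is therefore none beyond the scatter, with the reading most likely remaining a limit. Compound 4 is estimated at 60000 nM, within the range 20000 nM to 200000 nM.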

Compound 4, half-maximal inhibitory concentration: > 40000 nM
Compound 4: no number, only a limit; the forecaster's own chance of this, stated with the estimate: 80%; the middle value lies beyond the limit too.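

Compound 4 gives > 40000 nM in this assay, again a limit of the assay, so no step linking it to compound 1, compound 2 or compound 3 can be read: the limit of > 40000 nM in this assay, at which 4 of the 4 values shown sit.

The compounds shown leave open whether any aryl group on the aromatic nitrogen would give a readable value, and how these four compounds rank.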